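Notes: methyl for ethyl on the carboxycyclohexyl amide

The source may hold more compounds than are shown below. What is called first, only, known or untested is meant among the compounds shown, and "the series" means these compounds.

Measured in an ADME assay on microsomes from liver (Mus musculus) for metabolic stability, with a stated time of 10 min; a higher number here means that more of the compound is left, a lower number that less of the compound is left:
compound 1 (`CC[C@]1(C(=O)O)CC[C@H](C(=O)N2CC[C@](c3ccc(C(F)(C(F)(F)F)C(F)(F)F)cc3)(S(=O)(=O)c3ccc(F)cc3)C2)CC1`) : "not determined" (no result reported)
compound 2 (`C[C@]1(C(=O)N2CC[C@](c3ccc(C(F)(C(F)(F)F)C(F)(F)F)cc3)(S(=O)(=O)c3ccc(F)cc3)C2)CC[C@H](C(=O)O)CC1`) : 95%
compound 3 (`COC[C@]1(C(=O)N2CC[C@](c3ccc(C(F)(C(F)(F)F)C(F)(F)F)cc3)(S(=O)(=O)c3ccc(F)cc3)C2)CC[C@H](C(=O)O)CC1`) : 88%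

Compound 1 has no number to start from. Among the compounds with values here, its entry reads "not determined" (no result reported) and so no step can be counted from it, and its place stays open.

The move to compound 4 (`C[C@]1(C(=O)N2CC[C@](c3ccc(C(F)(C(F)(F)F)C(F)(F)F)cc3)(S(=O)(=O)c3ccc(F)cc3)C2)CC[C@@H](C(=O)O)CC1`) puts 4-carboxy-1-methylcyclohexyl in place of 4-carboxy-4-ethylcyclohexyl on a carbonyl carbon and leaves the rest of the core of compound 1 unchanged.

Within the data shown here, only one measured step is available as a guide. The step of a number 7 percentage points lower from compound 2 to compound 3 (within the scatter) comes from methoxy in place of hydrogen on a saturated chain carbon bound to a saturated ring carbon. It does not test the change made here, so it bears on it only indirectly. Its size gives no reason to expect a large move from a change on that same part of the molecule. The level is set by compound 2 at 95% and compound 3 at 88%, both close to the top of the scale.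

No step beyond the scatter from those two compounds is therefore expected in this assay, and no direction can be given. For compound 4 the expected value is 90%, with an estimated range from 77% to 100%.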

Compound 4, percent of the compound remaining: 100%
Compound 4: middle estimate off by 10 percentage points, on the low side; the range from low to high includes it.
By their numbers in this assay, from the lowest: compounds 3, 2 and 4 (each within the scatter of the next, the first and the last beyond it).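

In this assay, the two stereo forms carrying 4-carboxy-1-methylcyclohexyl show a number 5 percentage points higher from compound 2 to compound 4 (within the scatter), so the drawn configuration gives no readable difference in this assay, and this pair tests configuration alone: the fact that compounds 2 and 4 differ only in the configuration as drawn. The series also now has its first step beyond the scatter, with this assay showing a number 12 percentage points higher from compound 3 to compound 4 (beyond the scatter) on replacing 4-carboxy-1-(methoxymethyl)cyclohexyl with 4-carboxy-1-methylcyclohexyl, a modest step among values that all lie high on the scale. This step does not single out the methoxy group, since the comparison with the other methyl stereo form remains a number 7 percentage points lower from compound 2 to compound 3 (within the scatter), so compound 3 stands clearly apart only from compound 4.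

Steps involving compound 1 cannot be read, which leaves the place of 4-carboxy-4-ethylcyclohexyl in this series open. The compounds shown also leave open whether a longer chain such as propyl on the cyclohexyl group, or an amine in place of the carboxylic acid, would keep as much compound remaining in this assay.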